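The compounds below may be only part of what the source reports. "The series", "measured", "known", "first", "only" and "open" are said of these compounds alone.

Of the compounds shown here, three built on a shared core have been tested in a functional assay on A549 cells (Homo sapiens) for antiproliferative activity, read by MTT assay, with a stated time of 72 h; a lower number here means a stronger inhibitor, a higher number a weaker inhibitor. Compound 1 `COc1ccccc1-c1ccc2ncn(-c3cc(OC)c(OC)c(OC)c3)c2c1` gives 4320 nM. In this assay compound 2 `COc1cc(-n2cnc3ccc(-c4ccccc4)cc32)cc(OC)c1OC` gives 3060 nM. In this assay compound 3 `COc1cc(-n2cnc3ccc(-c4cccc(C)c4)cc32)cc(OC)c1OC` gives 3820 nM. The step of a 1.4-fold lower number from compound 1 to compound 2 (0.15 log units; within the scatter) takes away a methoxy on an aromatic carbon, the step of a 1.2-fold higher number from compound 2 to compound 3 (0.10 log units; within the scatter) adds a methyl on an aromatic carbon, and the step of a 1.1-fold lower number from compound 1 to compound 3 (0.05 log units; within the scatter) swaps one aryl group for another; none of them goes beyond the scatter. Compound 3 thus stands among values that cannot be told apart, with compound 1 nearest and compound 2 furthest, both within the scatter.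

Compound 4 `COc1cc(-n2cnc3ccc(-c4ccc(O)cc4)cc32)cc(OC)c1OC` has not yet been measured. It differs from compound 3 in one place: 4-hydroxyphenyl in place of 3-methylphenyl on an aromatic carbon. Going by the values given here, no measured step brings in a hydroxyl, so this change has no direct precedent in the data. The steps of a 1.4-fold lower number from compound 1 to compound 2 (0.15 log units; within the scatter), a 1.2-fold higher number from compound 2 to compound 3 (0.10 log units; within the scatter) and a 1.1-fold lower number from compound 1 to compound 3 (0.05 log units; within the scatter) all changed this aryl group and all stayed within the scatter. On that basis compound 4 is expected to show only a small step, a 1.1-fold lower number from compound 3 to compound 4 (0.04 log units; within the scatter), in either direction. In this assay compound 4 is estimated at 3500 nM, within a range from 1500 nM to 8000 nM.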

Compound 4, half-maximal inhibitory concentration: 5090 nM
Compound 4: middle estimate off by 1.5-fold (0.16 log units), on the low side; the measured number falls inside the stated range.
By their numbers in this assay, from the lowest: compounds 2, 3, 1 and 4 (each within the scatter of the next).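

In this assay, 4-hydroxyphenyl brings the first hydroxyl to this aromatic carbon of the shared core, and with it the first hydrogen-bond donor on this aryl group, yet the change stays within the scatter against all three earlier groups: 3-methylphenyl (a 1.3-fold higher number from compound 3 to compound 4 (0.12 log units; within the scatter)), hydrogen replaced by hydroxy on the phenyl ring (a 1.7-fold higher number from compound 2 to compound 4 (0.22 log units; within the scatter)) and 2-methoxyphenyl (a 1.2-fold higher number from compound 1 to compound 4 (0.07 log units; within the scatter)). Going by these compounds alone, the position thus now holds four different aryl groups, one of them carrying a hydroxyl, with no step that can be read as a real change. No accompanying measurement bears on this result.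

Going by these compounds, whether an amine, a carboxylic acid or a longer chain on this aryl group would move the number beyond the scatter remains open. So does whether any change at this position can do so.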